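Pyridine Attachment Swap in a Series at the Limit

The source may report more compounds than this note shows. Statements on the series, on what has been measured and on what is new or still open speak of the compounds shown alone.

compound 1 `C[C@H](Nc1ncnc2[nH]cnc12)c1nn(-c2ccncc2)c2cc(F)ccc12`: > 40000 nM, a limit of a functional assay on Bel-7402 cells (Homo sapiens) for inhibition, read by sulforhodamine B assay, with a stated time of 72 h; a higher number here means a weaker inhibitor, a lower number a stronger inhibitor
compound 2 `Cc1ccc2c(c1)c([C@H](C)Nc1ncnc3[nH]cnc13)nn2-c1cccnc1`: > 40000 nM, a limit
compound 3 `C[C@H](Nc1nc(N)nc2[nH]cnc12)c1nn(-c2cccnc2)c2cc(F)ccc12`: > 40000 nM, a limit

Compound 1 sits at the limit of > 40000 nM in this assay, at which 3 of the 3 values shown sit, so only a limit and no number is known for it, and compound 2 and compound 3 give the same kind of result. Compound 4 `C[C@H](Nc1ncnc2[nH]cnc12)c1nn(-c2ccccn2)c2cc(F)ccc12` differs from compound 1 in a single place: pyridin-2-yl in place of pyridin-4-yl on an aromatic nitrogen. Within the data shown here, since no compound in this set has a numbered value, no measured step shows how much such an exchange can move the result. The step of a number no higher from compound 1 to compound 4 (the limit leaves the size open) expected in this assay is none beyond the scatter. Compound 4 is expected to remain at the limit as well, estimated at 40000 nM, within 20000 nM to 80000 nM.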

Compound 4, half-maximal inhibitory concentration: > 40000 nM
Compound 4 ended at the assay's limit; the forecaster's own chance of this, stated with the estimate: 85%; the middle value lies on the limit itself.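

Compound 1 and compound 4 both end at a limit and not at a number, so no step between them can be read: the limit of > 40000 nM in this assay, at which 4 of the 4 values shown sit.

The compounds shown leave open how strongly any of them inhibits in this assay, and whether pyridin-2-yl and pyridin-4-yl differ at all.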